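Thiosemicarbazone series: aryl swap at the imine carbon

The compounds below may be only part of what the source reports. "The series", "measured", "known", "first", "only" and "open" are said of these compounds alone.

Measured so far:
compound 1 `CC1=CC[C@H](C(C)(C)NC(=S)N/N=C/c2cccc(Cl)c2)CC1`: 9200 nM
compound 2 `CC1=CC[C@H](C(C)(C)NC(=S)N/N=C/c2ccc(Cl)cc2)CC1`: 74900 nM

In a functional assay on 786-0 cells (Homo sapiens) for inhibition, read by sulforhodamine B assay, with a stated time of 48 h (a lower number here means a stronger inhibitor of growth, a higher number a weaker inhibitor of growth), compound 2 gives the highest of the two numbers; compound 1 sits nearer, and the step of an 8.1-fold higher number from compound 1 to compound 2 (0.91 log units; beyond the scatter) is modest yet beyond the scatter. Compound 3 `CC1=CC[C@H](C(C)(C)NC(=S)N/N=C/c2ccco2)CC1` carries the change (furan-2-yl in place of 4-chlorophenyl on a carbon with a double bond to nitrogen). Going by the values given here, no measured step exchanges a six-membered aromatic ring for a five-membered one, so only the size of the step from compound 1 to compound 2 guides the expectation for this assay. The estimate for compound 3 is 40000 nM (range 8000 nM to 150000 nM), an expected step of a 1.9-fold lower number from compound 2 to compound 3 (0.27 log units; within the scatter).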

Compound 3, concentration for 50% growth inhibition: 11700 nM
Beside the measured number, compound 3's estimate is 3.4-fold (0.53 log units) above it; the range from low to high includes it.
By their numbers in this assay, from the lowest: compounds 1 and 3 (each within the scatter of the next); then compound 2.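

The step of a 6.4-fold lower number from compound 2 to compound 3 (0.81 log units; beyond the scatter) shows that the loss seen with 4-chlorophenyl on a carbon with a double bond to nitrogen is not shared by every aryl group at this place. The step of a 1.3-fold higher number from compound 1 to compound 3 (0.10 log units; within the scatter) puts furan-2-yl level with 3-chlorophenyl, so a five-membered aromatic ring is tolerated here, and compound 2 alone stands apart. Still open, from the compounds shown here alone, is how a plain phenyl or a thiophene-2-yl group would read at this carbon. No evidence at hand accounts for these differences.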